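The source may report more compounds than this note shows. Statements on the series, on what has been measured and on what is new or still open speak of the compounds shown alone.

Working notes on the series. Compound 1 `CN1CCN(CCNC(=O)n2c(=O)n(Cc3ccccc3)c3ccccc32)CC1` has been run in a functional assay for agonist activity at 5-hydroxytryptamine receptor 4 (Cavia porcellus); on this read-out lower numbers stand for smaller maximal responses and higher numbers for larger maximal responses. In this assay compound 1 gives < 0.3, which is a limit of the assay and not a measured number. Compound 2 `CC(C)n1c(=O)n(C(=O)NCCN2CCN(C)CC2)c2cc(F)c(N)cc21` belongs to the same set. In this assay compound 2 likewise gives < 0.3, again a limit rather than a number. Among the compounds with values here, both values shown so far therefore sit at the limit of < 0.3 in this assay, at which 2 of the 2 values shown sit, and no step between measured compounds can be stated for the series; where compound 1 stands is known only as a limit.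

Compound 3 `CCCCn1c(=O)n(C(=O)NCCN2CCN(C)CC2)c2ccccc21` remains to be measured in this assay. It differs from compound 1 in one place: propyl in place of phenyl on a saturated chain carbon bound to an aromatic nitrogen. Cut one bond further out, the same change reads benzyl to butyl. Since compound 1 gives only < 0.3, any step to compound 3 can only be expected, not derived. The expected step from compound 1 to compound 3 is a step that the limit leaves unreadable from compound 1 to compound 3, that is, none beyond the scatter, the new value staying low. Compound 3 is estimated at 0.25, with a range from 0.1 to 0.5, and a further limit rather than a number is thought more likely than not.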

Compound 3, intrinsic activity: the largest response reached, as a fraction of the reference agonist's: < 0.3
Compound 3: a limit, no number; the forecaster's own chance of this, stated with the estimate: 60%; the middle value is on the limit's open side.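

In this assay compound 3 gives < 0.3, a limit of the assay and not a number. No step from compound 1 to compound 3 can be read, as both carry only limits: the limit of < 0.3 in this assay, at which 3 of the 3 values shown sit.

The compounds shown leave open whether benzyl to butyl changes the maximal response at all, as none of them has a measured number.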